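The source may hold more compounds than are shown below. What is called first, only, known or untested is meant among the compounds shown, and "the series" means these compounds.

Measured in a functional assay on L1210 cells (Mus musculus) for inhibition; on this read-out higher numbers stand for weaker inhibition and lower numbers for stronger inhibition:
- Compound 1 `C=Cc1cc(=O)[nH]c(=O)n1C1O[C@H](CO)[C@@H](O)[C@H]1O`: 12000 nM
- Compound 2 `CCOC(=O)/C=C/c1cc(=O)[nH]c(=O)n1C1O[C@H](CO)[C@@H](O)[C@H]1O`: > 35000 nM (a limit)

Compound 2 sits at the limit of > 35000 nM in this assay, at which 1 of the 2 values shown sits, so it has a limit and no number. Compound 3 `COC(=O)/C(Br)=C\c1cc(=O)[nH]c(=O)n1C1O[C@H](CO)[C@@H](O)[C@H]1O` differs from it by 2-bromo-2-(methoxycarbonyl)ethenyl in place of 2-(ethoxycarbonyl)ethenyl on an aromatic carbon, with 2-bromo-2-(methoxycarbonyl)ethenyl in place of 2-(ethoxycarbonyl)ethenyl on an aromatic carbon.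

For the measured compounds named here, the only measured step that bears on this change is an at least 2.9-fold higher number from compound 1 to compound 2 (0.46 log units; beyond the scatter), which is beyond the scatter. Going by the values given here, no measured compound carries bromine. Compound 3 retains a carbonyl-bearing ethenyl, and that kind of group arrived with an at least 2.9-fold higher number from compound 1 to compound 2 (0.46 log units; beyond the scatter), so in this assay a weak result near the limit is expected, with no clear step beyond the scatter. The expected step is an at least 1.1-fold lower number from compound 2 to compound 3 (0.06 log units; that floor lies within the scatter). For compound 3 the estimated value is 30000 nM, with an expected range of 9000 nM to 100000 nM.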

Compound 3, half-maximal inhibitory concentration: > 25000 nM
Compound 3: only a limit was reported; the forecaster's own chance of this, stated with the estimate: 50%; the middle value is on the limit's open side.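

In this assay, a second carbonyl-bearing ethenyl on this aromatic carbon again gives only a limit, now with bromine on the chain: the value for compound 3 is a limit and not a number. Putting 2-bromo-2-(methoxycarbonyl)ethenyl in place of vinyl gives an at least 2.0-fold higher number from compound 1 to compound 3 (0.31 log units; beyond the scatter), so the weaker reading seen with 2-(ethoxycarbonyl)ethenyl is not confined to that one group. The step between compound 2 and compound 3 cannot be read, as both values are limits, so the effect of adding bromine and shortening the ethoxycarbonyl to methoxycarbonyl remains unsized.

Going by these compounds, whether bromine on a plain ethenyl without any carbonyl would read differently from vinyl remains open. So does how an amine, a carboxylic acid or a longer alkyl chain at this position would compare with compound 1.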